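This account rests on a few compounds, and the source may have more. Where it says the series, first, only, none or still open, it means among the compounds named here.

Compound 1 `COc1cc(-c2nccn3cc(-c4ccc(F)cc4)nc23)cc(OC)c1OC`, compound 2 `COc1cc(-c2nccn3cc(-c4ccc(Cl)cc4)nc23)cc(OC)c1OC` and compound 3 `COc1cc(-c2nccn3cc(-c4ccc(O)cc4)nc23)cc(OC)c1OC` share one core and differ only in a single group on an aromatic carbon. In a functional assay on A549 cells (Homo sapiens) for inhibition, read by MTT assay, with a stated time of 48 h (on this read-out higher numbers stand for weaker inhibition and lower numbers for stronger inhibition), compound 1 gives 137 nM and compound 2 gives 7290 nM. For compound 3 this assay reports only a limit, > 10000 nM, so compound 3 stands at the weak end of the numbers shown. Compound 4 `COc1cc(-c2nccn3cc(-c4ccc(C)cc4)nc23)cc(OC)c1OC` carries the change (methyl in place of hydroxy on an aromatic carbon). The measured steps that bear on it each bring in the hydroxy: an at least 72-fold higher number from compound 1 to compound 3 (1.86 log units; beyond the scatter) and an at least 1.3-fold higher number from compound 2 to compound 3 (0.13 log units; that floor lies within the scatter), while the halogen swap a 53-fold higher number from compound 1 to compound 2 (1.73 log units; beyond the scatter) shows how far one group can move the number. Compound 4 is therefore expected to show a lower number, an estimated step of an at least 3.3-fold lower number from compound 3 to compound 4 (0.52 log units; beyond the scatter). Compound 4 is expected to give about 3000 nM, likely between 400 nM and 20000 nM.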

Compound 4, half-maximal inhibitory concentration: 135 nM
Compound 4: middle estimate off by 22-fold (1.35 log units), on the high side; measured number below the stated range.
By their numbers in this assay, from the lowest: compounds 4 and 1 (each within the scatter of the next); then compound 2. At a limit, above all of these: compound 3.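

Para to a large group, methyl and fluoro leave the number in the same place, with a 1.0-fold lower number from compound 1 to compound 4 (0.01 log units; within the scatter). Chloro at this position stands well apart from methyl, with a 54-fold lower number from compound 2 to compound 4 (1.73 log units; beyond the scatter), so the one-atom groups shown do not all behave alike here. The step of an at least 74-fold lower number from compound 3 to compound 4 (1.86 log units; beyond the scatter) is only a floor, since the value of compound 3 is a limit: the limit of > 10000 nM in this assay, at which 1 of the 4 values shown sits.

The compounds shown leave open whether an amine or a longer chain such as ethyl at this position would stay with compound 1 and compound 4 or fall nearer compound 2. They also cannot tell why chloro and methyl differ so widely.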